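A few compounds are considered here, and "the series" means these few. Any claim that something is new, unique, unknown or untested is made for them only; others in the source may bear on it.

Within the data shown here, only two compounds have been measured so far. In a functional assay on MCF7 cells (Homo sapiens) for antiproliferative activity, read by MTT assay, with stated times of 24 h and 72 h (a lower number here means a stronger inhibitor, a higher number a weaker inhibitor), compound 1 `COc1ccc([C@@H]2[C@@H](Oc3ccccc3)C(=O)N2c2cc(OC)c(OC)c(OC)c2)cc1N` gives 13 nM as its result, while compound 2 `COc1ccc([C@@H]2[C@H](Oc3ccccc3)C(=O)N2c2cc(OC)c(OC)c(OC)c2)cc1OP(=O)(O)O` gives 42000 nM as its result. Compound 2 therefore holds the higher of the two numbers, making it the weaker inhibitor by a margin far beyond the usual scatter of repeat measurements.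

Compound 3 `COc1ccc([C@@H]2[C@@H](Oc3ccccc3)C(=O)N2c2cc(OC)c(OC)c(OC)c2)cc1OP(=O)(O)O` is a close relative of compound 2. The change is small on paper: the two compounds have the same atoms and bonds and differ only in configuration as drawn: 1 of 2 stereo elements differ; a stereocentre at a saturated ring carbon is drawn S in compound 2 and R in compound 3 is the whole of the difference, so only the spatial arrangement at that one carbon is altered. Among the measured compounds shown here, no measured pair shows what such a change does here, which leaves the expectation loose. Compound 2 sits at the weak end of the numbers, and compound 1 at 13 nM shows that far lower values occur, so a move towards stronger inhibition is expected, and it is likely to lie beyond the scatter.

The expected change is a 110-fold lower number from compound 2 to compound 3 (2.02 log units; beyond the scatter) in size, though this is only a rough estimate. For compound 3 the estimated value is 400 nM in this assay with an expected range from 20 nM to 15000 nM as its limits.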

Compound 3, half-maximal inhibitory concentration: 23000 nM
Compound 3: middle estimate off by 58-fold (1.76 log units), on the low side; measured number outside the range, above it.
By their numbers in this assay, from the lowest: compound 1; then compounds 3 and 2 (each within the scatter of the next).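

In this assay, among these compounds, this is the first reading of what the stereocentre at the saturated ring carbon does, and the step is a 1.8-fold lower number from compound 2 to compound 3 (0.26 log units; within the scatter), so the S and R forms carrying the phosphorus-containing group cannot be told apart here. The two numbers are therefore a direct comparison of this single change, with nothing else altered between the structures: the fact that compounds 2 and 3 differ only in the configuration as drawn. Compound 3 also gives the first clean comparison at the aromatic carbon, where a group of 5 heavy atoms (4 oxygen, 1 phosphorus; no ring) in place of one nitrogen atom comes with a 1800-fold higher number from compound 1 to compound 3 (3.25 log units; beyond the scatter), so among these three compounds the large difference goes with that swap and not with the stereocentre.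

The compounds shown leave open whether the stereocentre matters equally little when the aromatic carbon carries the single nitrogen atom of compound 1, since the flat result holds only for the pair with the larger group. They also leave open how the number moves across other groups at that aromatic carbon, such as a hydroxyl group or a carboxylic acid, which would show whether the large step is gradual or abrupt.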